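A few compounds are considered here, and "the series" means these few. Any claim that something is new, unique, unknown or untested is made for them only; others in the source may bear on it.

Among the two compounds measured in a functional assay on PC-3 cells (Homo sapiens) for inhibition, read by sulforhodamine B assay, with a stated time of 48 h (a lower number here means a stronger inhibitor of growth, a higher number a weaker inhibitor of growth), compound 2 `COc1ccc(/C=N/NC(=S)NC(C)(C)[C@H]2CC=C(C)CC2)cc1` gives 1200 nM, the lowest number seen; compound 1 `CC1=CC[C@H](C(C)(C)NC(=S)N/N=C/c2ccccc2)CC1` gives 5700 nM. For the measured compounds named here, the one measured step, a 4.8-fold lower number from compound 1 to compound 2 (0.68 log units; beyond the scatter), came from putting a methoxy group onto the aromatic ring. Compound 3 `CC1=CC[C@H](C(C)(C)NC(=S)N/N=C/c2ccc(O)cc2)CC1` differs from compound 2 by hydrogen in place of methyl on an oxygen on an aromatic ring. Going by the values given here, no measured step covers methoxy to hydroxy, so that earlier step only hints that this part of the molecule matters, and a change in either direction is expected to stay modest, a 1.5-fold higher number from compound 2 to compound 3 (0.18 log units; within the scatter). Compound 3 is therefore expected to give about 1800 nM, between 700 nM and 5000 nM.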

Compound 3, concentration for total growth inhibition: 53800 nM
The estimate for compound 3 lay 30-fold (1.48 log units) below the measured number, and the stated range ends below it.
By their numbers in this assay, from the lowest: compound 2; then compound 1; then compound 3.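

The methyl on this oxygen carries far more weight than the earlier step suggested: losing it gives a 45-fold higher number from compound 2 to compound 3 (1.65 log units; beyond the scatter) in this assay. Replacing hydrogen on the aromatic carbon with hydroxy also gives a 9.4-fold higher number from compound 1 to compound 3 (0.97 log units; beyond the scatter), the opposite direction from the methoxy step, so the two oxygen-linked groups are not interchangeable here. No evidence shown accounts for this gap between methoxy and hydroxy. Still open, going by these compounds, is whether a longer chain on the oxygen, as in ethoxy, would behave like methoxy. On these data alone, an amine in place of hydroxy is equally open.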